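This account rests on a few compounds, and the source may have more. Where it says the series, first, only, none or still open, it means among the compounds named here.

Measured so far in a functional assay on MDA-MB-231 cells (Homo sapiens) for cytotoxicity, read by MTT assay, with a stated time of 48 h; on this read-out higher numbers stand for weaker inhibition and lower numbers for stronger inhibition:
- compound 1 `COc1ccc(C2=NOC(COc3ccc(-c4nnnn4-c4cc(OC)c(OC)c(OC)c4)cc3N)C2)cc1O`: 3380 nM
- compound 2 `COc1cc(-n2nnnc2-c2ccc(OCC3CC(c4ccccc4F)=NO3)c(N)c2)cc(OC)c1OC`: 2400 nM

Among the compounds with values here, compound 2 gives 2400 nM in this assay, and this value lies within the scatter of the one for compound 1, so the two cannot be ranked. The next compound is compound 3 `COc1cc(-n2nnnc2-c2ccc(OCC3CC(c4cccc(Cl)c4)=NO3)c(N)c2)cc(OC)c1OC`, which has 3-chlorophenyl in place of 2-fluorophenyl on a carbon with a double bond to nitrogen. Within the data shown here, only one measured step bears on this change, as it swaps the aryl group at the same place: replacing 3-hydroxy-4-methoxyphenyl with 2-fluorophenyl gave a 1.4-fold lower number from compound 1 to compound 2 (0.15 log units; within the scatter). Among the measured compounds shown here, no measured compound carries a chlorine, so that single small step is the only guide. Since the step from compound 1 stayed within the scatter, no shift beyond the scatter is expected in this assay here, and no direction can be favoured. The expected step is a 1.1-fold lower number from compound 2 to compound 3 (0.04 log units; within the scatter). For compound 3 the estimated value is 2200 nM, with an expected range from 800 nM to 6500 nM.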

Compound 3, half-maximal inhibitory concentration: 2180 nM
Beside the measured number, compound 3's estimate is 1.0-fold (0.00 log units) above it; measured number inside the range.
By their numbers in this assay, from the lowest: compounds 3, 2 and 1 (each within the scatter of the next).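

In this assay, replacing 2-fluorophenyl with 3-chlorophenyl on the carbon with a double bond to nitrogen gives a 1.1-fold lower number from compound 2 to compound 3 (0.04 log units; within the scatter), and replacing 3-hydroxy-4-methoxyphenyl with 3-chlorophenyl gives a 1.6-fold lower number from compound 1 to compound 3 (0.19 log units; within the scatter). This position has now carried three different substituted phenyl groups, including one with chlorine in place of fluorine and one with hydroxy and methoxy groups, and none of the listed steps leaves the scatter, so these compounds cannot be ranked by the group at this position. No measurement is available that could explain this lack of separation between the compounds.

Going by these compounds, all three compounds keep a substituted phenyl ring at this position, so it remains open whether a cyclohexyl ring, a morpholine or a carboxylic acid there would produce a step beyond the scatter. The 2-fluorophenyl to 3-chlorophenyl change also alters the halogen and its place on the ring together, so the compounds shown cannot separate these two changes, and the amino group on the core stays the same throughout.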